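Adding a Methyl Group to Compound 2

The source may report more compounds than this note shows. Statements on the series, on what has been measured and on what is new or still open speak of the compounds shown alone.

Compound 2 `C[C@@H](NC(=O)Nc1ccc(F)cc1)c1ccccc1` has been measured in an ADME assay on the whole organism with Oryza sativa as the target, tested at 10 uM (a higher number here means a weaker effect of the compound at the concentration tested, a lower number a stronger effect), where compound 2 gives 92%. Among the measured compounds shown here, its only measured neighbour is compound 1 `CCCCCCc1ccc(NC(=O)N[C@H](C)c2ccccc2)cc1`, which in this assay gives 101%; the difference between them lies within the scatter, so neither can be called the stronger. For the measured compounds named here, the one measured step, a number 9 percentage points lower from compound 1 to compound 2 (within the scatter), came from a fluoro in place of hexyl on an aromatic carbon. Both numbers show that these compounds have little effect at the concentration tested.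

Compound 3 `Cc1cc(F)ccc1NC(=O)N[C@H](C)c1ccccc1` differs from compound 2 in one place: methyl in place of hydrogen on an aromatic carbon. Going by the values given here, no measured step involves a methyl in place of hydrogen, so the step from compound 1 to compound 2 bears on it only loosely: it shows that swapping a hexyl for a fluoro on this ring left the number within the scatter. Adding a single carbon is a smaller change, so no shift beyond the scatter is expected in this assay. Compound 3 is therefore expected to give 95%, within 80% to 108%. The step expected from this change, a number 3 percentage points higher from compound 2 to compound 3 (within the scatter), is small.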

Compound 3, a percentage reported as activity, at one concentration (the size of the read-out at that concentration, not a potency): 94%
Compound 3: the middle estimate sits 1 percentage points above what was measured; low and high end bracket the measured number.
By their numbers in this assay, from the lowest: compounds 2, 3 and 1 (each within the scatter of the next).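

The step of a number 2 percentage points higher from compound 2 to compound 3 (within the scatter) is the only one shown at this position, an aromatic carbon ortho to a large group and meta to a fluoro group, and it gives no sign that a methyl in place of hydrogen there matters in this assay. The earlier step concerned the carbon that carries the fluoro group, so a second place on the same ring has now been changed, again with a result inside the scatter. No measurement at hand offers an explanation for either result.

On these data alone, whether an ethyl, a methoxy, an amine or a carboxylic acid on this same carbon would move the number beyond the scatter remains open. Also open, as far as these compounds go, is whether any change to the shared core, rather than to the groups on this ring, would give a number clearly apart from those of compound 1, compound 2 and compound 3.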